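The compounds below may be only part of what the source reports. "The series", "measured", "known", "first", "only" and "open" are said of these compounds alone.

Working notes on the chain-varied series. Compound 1 `O=c1c(-c2ccc(O)cc2)coc2cc(OCCCCCCCCCO)ccc12` carries a hydroxy-terminated chain, and in an assay (Cricetulus griseus) for inhibition of aldehyde dehydrogenase, mitochondrial (Homo sapiens) (on this read-out lower numbers stand for stronger inhibition and higher numbers for weaker inhibition), compound 1 gives 700 nM. Compound 2 `NCCCCOc1ccc2c(=O)c(-c3ccc(O)cc3)coc2c1`, with a shorter amino-terminated chain, gives 250 nM. Compound 3 `CCCCCCCCCCCCOc1ccc2c(=O)c(-c3ccc(O)cc3)coc2c1` carries an unsubstituted dodecyl chain. For compound 3 only a limit of this assay is recorded, > 9000 nM, placing it at the weak end of the set (the limit of > 9000 nM in this assay, at which 1 of the 3 values shown sits). Compound 4 `O=C(O)CCCCCCCCCOc1ccc2c(=O)c(-c3ccc(O)cc3)coc2c1` differs from compound 3 by carboxy in place of propyl on a saturated chain carbon, nine bonds along the chain from an oxygen on an aromatic ring. Among the compounds with values here, two measured steps bear on this: an at least 12-fold higher number from compound 1 to compound 3 (1.10 log units; beyond the scatter) and an at least 36-fold higher number from compound 2 to compound 3 (1.55 log units; beyond the scatter), both showing that exchanging a hydroxy or amino terminus for alkyl raised the number markedly. Reintroducing a hydrogen-bond donor and acceptor at the chain end should reverse much of this, so compound 4 is expected to show a large downward step, an at least 9.0-fold lower number from compound 3 to compound 4 (0.95 log units; beyond the scatter). Compound 4 is estimated at 1000 nM, within 300 nM to 5000 nM.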

Compound 4, half-maximal inhibitory concentration: 50 nM
Estimate against measurement, compound 4: 20-fold (1.30 log units) above; measured number below the stated range.
By their numbers in this assay, from the lowest: compound 4; then compound 2; then compound 1. At a limit, above all of these: compound 3.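

Against hydroxy at the same chain end, carboxy gives a 14-fold lower number from compound 1 to compound 4 (1.15 log units; beyond the scatter) and so does more than recover what the alkyl terminus lost. The shorter amino-terminated chain also gives way, with a 5.0-fold lower number from compound 2 to compound 4 (0.70 log units; beyond the scatter) but that step changes chain length and terminus together. The step of an at least 180-fold lower number from compound 3 to compound 4 (2.25 log units; beyond the scatter) is only a bound, as compound 3 stands at a limit: the limit of > 9000 nM in this assay, at which 1 of the 4 values shown sits.

As far as these compounds go, whether an amine on the longer chain or a carboxylic acid on a shorter chain would match compound 4 stays open. From the compounds shown here alone, whether an ester or amide at the chain end would keep the gain also stays open.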